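From fluoro to bromo: compound 3 to compound 4

This account rests on a few compounds, and the source may have more. Where it says the series, first, only, none or still open, it means among the compounds named here.

In a functional assay (Nicotiana tabacum) (on this read-out higher numbers stand for weaker inhibition and lower numbers for stronger inhibition), compound 3 (`CSc1nc(Nc2ccc(F)cc2)c2cccnc2n1`) gives 2620 nM and lies within the scatter of compound 1 (`CCCCCCNc1nc(SC)nc2ncccc12`) at 3330 nM in this small set. Compound 2 (`CSc1nc(NC2CCC2)c2cccnc2n1`) at 720 nM stands lower than both, beyond the scatter. Compound 4 (`CSc1nc(Nc2ccc(Br)cc2)c2cccnc2n1`) differs from compound 3 by a single exchange (bromo in place of fluoro on an aromatic carbon): bromo in place of fluoro on an aromatic carbon, para to a large group. Among the measured compounds shown here, the only measured step, a 4.6-fold lower number from compound 1 to compound 2 (0.67 log units; beyond the scatter) for cyclobutyl in place of hexyl on a nitrogen on an aromatic ring, is modest and lies at a different place, so it does not bear directly on this exchange. For the measured compounds named here, no measured pair swaps one halogen for another, so the data give neither size nor direction for it. The expected change in this assay is therefore a 1.0-fold lower number from compound 3 to compound 4 (0.02 log units; within the scatter) and no step beyond the scatter in either direction. For compound 4 an estimated 2500 nM follows, with 1000 nM to 6000 nM as the expected range.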

Compound 4, half-maximal inhibitory concentration: 5750 nM
The estimate for compound 4 lay 2.3-fold (0.36 log units) below the measured number; the measured number falls inside the stated range.
By their numbers in this assay, from the lowest: compound 2; then compounds 3, 1 and 4 (each within the scatter of the next, the first and the last beyond it).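

In this assay, the place on the aromatic ring para to a large group is not indifferent to the halogen: bromo in place of fluoro on an aromatic carbon gives a 2.2-fold higher number from compound 3 to compound 4 (0.34 log units; beyond the scatter). Among the compounds shown here, this is the first measured exchange at this place, and its direction is towards weaker inhibition, though the step is modest. The two groups match in the counted features (heavy atoms, hydrogen-bond donors, hydrogen-bond acceptors, net charge), and no available evidence accounts for the step.

As far as these compounds go, whether chloro at the same place would fall between fluoro and bromo remains open, as does how an unsubstituted ring, a methoxy group or a nitrile would compare. Also open, from the compounds shown here alone, is whether the step from fluoro to bromo keeps its size and direction with other groups on the shared core.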